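The source may hold more compounds than are shown below. What is called first, only, known or untested is meant among the compounds shown, and "the series" means these compounds.

Two amides on a shared core have been measured in an assay on isolated protein for agonist activity at melatonin receptor type 1C (Xenopus laevis), read by spectrophotometry; a higher number here means that more compound is needed for the effect, a lower number that less compound is needed: compound 1, `CCCC(=O)NCc1cc(OC)ccc1F`, gives 1350 nM, and compound 2, `COc1ccc(CNC(C)=O)cc1F`, gives 1510 nM, the larger of the two numbers, although its gap to compound 1 lies within the scatter. Compound 3, `CCC(=O)NCc1ccc(OC)c(F)c1`, carries methyl in place of hydrogen on a saturated chain carbon bound to a carbonyl carbon, acetyl to propanoyl. Among the compounds with values here, no measured pair shows this change, so for compound 3 only a small move is expected, perhaps towards a lower number, with the step from compound 2 to compound 3 estimated as a 1.5-fold lower number from compound 2 to compound 3 (0.18 log units; within the scatter). Compound 3 is thus expected to give about 1000 nM, within 400 nM to 2500 nM.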

Compound 3, half-maximal effective concentration: 1050 nM
Compound 3: middle estimate off by 1.1-fold (0.02 log units), on the low side, within the range that was stated.
By their numbers in this assay, from the lowest: compounds 3, 1 and 2 (each within the scatter of the next).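

In this assay the change of acetyl to propanoyl, methyl in place of hydrogen on a saturated chain carbon bound to a carbonyl carbon, now has a measured size, with a 1.4-fold lower number from compound 2 to compound 3 (0.16 log units; within the scatter) as its step. At this place, then, the added methyl leaves the number within the scatter, so acetyl and propanoyl are not told apart. Nothing available explains this result. Going by these compounds, what an amine or a hydroxyl group would do at this same place stays open, as does whether a second methyl on that carbon would give a step beyond the scatter.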